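The source may hold more compounds than are shown below. What is called first, only, known or untested is meant among the compounds shown, and "the series" means these compounds.

Compound 1 `CC#CCn1c(N2CCC[C@@H](N)C2)nc2c1c(=O)n(CCCN1CCN(c3nc(-c4ccccc4)cs3)CC1)c(=O)n2C` is the reference point. Going by the values given here, in a functional assay on HEK293 cells for agonist activity at Glucose-dependent insulinotropic receptor (Homo sapiens), read by a luciferase reporter (on this read-out higher numbers stand for an effect only at larger amounts of compound and lower numbers for an effect already at smaller amounts), compound 1 gives 650 nM, the lowest of the three numbers measured so far. Compound 3 `CC#CCn1c(N2CCC[C@@H](N)C2)nc2c1c(=O)n(CCCN1CCN(c3noc(-c4ccccc4)n3)CC1)c(=O)n2C`, which carries a different aromatic group on the amine nitrogen of the six-membered ring, gives 1450 nM in this assay, and compound 2 `CC#CCn1c(N2CCC[C@@H](N)C2)nc2c1c(=O)n(CCCN1CCC(c3nc(-c4ccccc4)cs3)CC1)c(=O)n2C`, in which that ring holds one nitrogen instead of two, gives 3130 nM. Among the compounds with values here, the only measured step that changes one place is a 2.2-fold higher number from compound 1 to compound 3 (0.35 log units; beyond the scatter), a swap of one aromatic group for another at the same ring nitrogen.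

Compound 4 `CC#CCn1c(N2CCC[C@@H](N)C2)nc2c1c(=O)n(CCCN1CCN(c3ncc(CCC)cn3)CC1)c(=O)n2C` changes the same place: 5-propylpyrimidin-2-yl in place of 4-phenyl-1,3-thiazol-2-yl on an amine nitrogen in a ring. This is again a swap of the aromatic group on the ring amine nitrogen, so the step from compound 1 to compound 3 is the closest guide. That step gave a modest weakening beyond the scatter, and a similar outcome is expected here, as a 2.3-fold higher number from compound 1 to compound 4 (0.36 log units; beyond the scatter). Compound 4 is therefore estimated at 1500 nM in this assay, within a range of 500 nM to 4500 nM.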

Compound 4, half-maximal effective concentration: 1850 nM
Estimate against measurement, compound 4: 1.2-fold (0.09 log units) below; low and high end bracket the measured number.
By their numbers in this assay, from the lowest: compound 1; then compounds 3, 4 and 2 (each within the scatter of the next, the first and the last beyond it).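

In this assay the ring amine nitrogen also accepts a group built quite differently from the two earlier ones: 5-propylpyrimidin-2-yl has one six-membered aromatic ring with a propyl chain rather than two linked aromatic rings, and it gives a 2.8-fold higher number from compound 1 to compound 4 (0.45 log units; beyond the scatter) while still leaving a measurable effect. Set against the 5-phenyl-1,2,4-oxadiazol-3-yl group, the same change gives a 1.3-fold higher number from compound 3 to compound 4 (0.11 log units; within the scatter) so these two groups cannot be told apart here, and both give higher numbers than the 4-phenyl-1,3-thiazol-2-yl group of compound 1. The data shown offer no measurement that explains these differences.

From the compounds shown here alone, what the propyl chain itself contributes remains open, and a 5-ethyl or 5-butyl chain on the same pyrimidine ring would test it. Also open, going by these compounds, is whether a phenyl group in place of that chain would bring the number back towards that of compound 1.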